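This account rests on a few compounds, and the source may have more. Where it says the series, first, only, none or still open, it means among the compounds named here.

Compound 1 `COc1ccc(/C=N/NC(=O)CSc2nnc(-c3ccncc3)o2)cc1` is the weakest of the three measured compounds in a functional assay on HepG2 cells (Homo sapiens) for cytotoxicity, read by MTT assay, with a stated time of 48 h (on this read-out lower numbers stand for stronger inhibition and higher numbers for weaker inhibition), where compound 1 gives 15800 nM. Compound 2 `O=C(CSc1nnc(-c2ccncc2)o1)N/N=C/c1cc(Cl)cc(Cl)c1O` gives 3260 nM in this assay, and compound 3 `COc1cc(/C=N/NC(=O)CSc2nnc(-c3ccncc3)o2)ccc1O` gives 2920 nM. The two measured steps from compound 1 are both modest: a 4.8-fold lower number from compound 1 to compound 2 (0.69 log units; beyond the scatter) and a 5.4-fold lower number from compound 1 to compound 3 (0.73 log units; beyond the scatter), and the two products sit within the scatter of each other, as a 1.1-fold lower number from compound 2 to compound 3 (0.05 log units; within the scatter) shows.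

Compound 4 `O=C(CSc1nnc(-c2ccncc2)o1)N/N=C/C=C/c1ccccc1` differs from compound 1 in one place: 2-phenylethenyl in place of 4-methoxyphenyl on a carbon with a double bond to nitrogen. Both measured steps replaced 4-methoxyphenyl with a hydroxy-bearing aryl group, 3,5-dichloro-2-hydroxyphenyl or 4-hydroxy-3-methoxyphenyl, whereas compound 4 brings in 2-phenylethenyl, which carries no hydrogen-bond acceptor. Among the measured compounds shown here, no measured step therefore bears directly on this change. With nothing in the data to favour a shift in either direction, compound 4 is expected to stay close to compound 1, with a 1.1-fold lower number from compound 1 to compound 4 (0.05 log units; within the scatter) not beyond the scatter. The estimate for compound 4 in this assay is 14000 nM, in the range 4500 nM to 45000 nM.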

Compound 4, half-maximal inhibitory concentration: 7420 nM
Compound 4: middle estimate off by 1.9-fold (0.28 log units), on the high side; measured number inside the range.
By their numbers in this assay, from the lowest: compounds 3 and 2 (each within the scatter of the next); then compound 4; then compound 1.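

In this assay the change to 2-phenylethenyl gives a 2.1-fold lower number from compound 1 to compound 4 (0.33 log units; beyond the scatter) and so shows that a lower number at this position, on a carbon with a double bond to nitrogen, does not depend on a hydroxy-bearing aryl group. The hydroxy-bearing groups still give lower numbers, as a 2.5-fold higher number from compound 3 to compound 4 (0.41 log units; beyond the scatter) and a 2.3-fold higher number from compound 2 to compound 4 (0.36 log units; beyond the scatter) show, which places compound 4 between compound 1 and that pair. No measurement shown here accounts for these differences.

The compounds shown leave open what a saturated 2-phenylethyl chain would give at this place, and with it whether the double bond outside aromatic rings matters for the number of compound 4. They also leave open what an amine or a carboxylic acid on this carbon would give.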